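Replacing a bromophenyl with a hydroxylated ring on the hydrazone

The source may hold more compounds than are shown below. What is called first, only, known or untested is meant among the compounds shown, and "the series" means these compounds.

Compound 1 `CN(C)CCn1cnnc1-c1cc(Oc2ccc(NC(=O)N/N=C/c3ccc(Cl)cc3Cl)cc2F)ccn1`: 810 nM
Compound 2 `CN(C)CCn1cnnc1-c1cc(Oc2ccc(NC(=O)N/N=C/c3ccc(O)c(O)c3)cc2F)ccn1`: > 100000 nM, a limit
Compound 3 `CN(C)CCn1cnnc1-c1cc(Oc2ccc(NC(=O)N/N=C/c3cccc(Br)c3)cc2F)ccn1`: 970 nM

In a functional assay on A549 cells (Homo sapiens) for cytotoxicity, read by MTT assay, with a stated time of 72 h (on this read-out higher numbers stand for weaker inhibition and lower numbers for stronger inhibition), compound 1 gives 810 nM and compound 3 gives 970 nM. Compound 2 reaches only > 100000 nM, which is a limit of the assay and not a number (the limit of > 100000 nM in this assay, at which 1 of the 3 values shown sits). Compound 3 therefore holds the higher of the two numbers, though compound 1 sits within the scatter of it a 1.2-fold higher number from compound 1 to compound 3 (0.08 log units; within the scatter).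

Compound 4 `Cc1cc(/C=N/NC(=O)Nc2ccc(Oc3ccnc(-c4nncn4CCN(C)C)c3)c(F)c2)cc(C)c1O` differs from compound 3 in one place: 4-hydroxy-3,5-dimethylphenyl in place of 3-bromophenyl on a carbon with a double bond to nitrogen. Going by the values given here, two measured steps bear on this. Moving to a hydroxylated ring gave an at least 120-fold higher number from compound 1 to compound 2 (2.09 log units; beyond the scatter), and moving away from it gave an at least 100-fold lower number from compound 2 to compound 3 (2.01 log units; beyond the scatter). Compound 4 carries one hydroxyl and two methyl groups rather than two hydroxyls, so a smaller rise is expected and the estimated step is an 8.2-fold higher number from compound 3 to compound 4 (0.92 log units; beyond the scatter). Compound 4 is estimated at 8000 nM, between 1500 nM and 100000 nM.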

Compound 4, half-maximal inhibitory concentration: 1640 nM
The estimate for compound 4 lay 4.9-fold (0.69 log units) above the measured number; measured number inside the range.
By their numbers in this assay, from the lowest: compounds 1, 3 and 4 (each within the scatter of the next, the first and the last beyond it). At a limit, above all of these: compound 2.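

The ring on the carbon with a double bond to nitrogen can carry a hydroxyl and still keep cell activity, so a single hydroxyl does not by itself bring the loss seen with compound 2: 4-hydroxy-3,5-dimethylphenyl gives a 1.7-fold higher number from compound 3 to compound 4 (0.23 log units; within the scatter), and a 2.0-fold higher number from compound 1 to compound 4 (0.31 log units; beyond the scatter). Set against 3,4-dihydroxyphenyl, the same ring gives an at least 60-fold lower number from compound 2 to compound 4 (1.78 log units; beyond the scatter). Compound 2 stands at a limit and not at a number: the limit of > 100000 nM in this assay, at which 1 of the 4 values shown sits.

As far as these compounds go, whether the second hydroxyl or the two methyl groups separate compound 2 from compound 4 stays open. So does how an amine or a carboxylic acid on this ring would behave.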